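Swapping the Sulfur-Linked Heterocycle in a Thiazolylidene Hydrazide Series

The source may hold more compounds than are shown below. What is called first, only, known or untested is meant among the compounds shown, and "the series" means these compounds.

Measured compounds and values:
compound 1, `O=C(CSc1nnnn1-c1ccccc1)N/N=c1/scc(-c2ccc(Br)cc2)n1-c1ccccc1`, 20.4%
compound 2, `Cc1ccc(-c2cs/c(=N/NC(=O)CSc3nnnn3-c3ccccc3)n2-c2ccccc2)cc1`, 22.2%
compound 3, `O=C(CSc1nnnn1-c1ccccc1)N/N=c1/scc(-c2ccc(Cl)cc2)n1-c1ccccc1`, 52.4%

In a functional assay on C6 cells (Rattus norvegicus) for cytotoxicity, read by MTT assay, with a stated time of 24 h, tested at 200 ug/mL (on this read-out lower numbers stand for a stronger effect and higher numbers for a weaker effect at the one concentration tested), compound 1 gives 20.4%, the lowest of the three numbers. Its nearest neighbour is compound 2, which gives 22.2%; the step of a number 1.8 percentage points higher from compound 1 to compound 2 (within the scatter) lies within the scatter. Compound 3 gives 52.4%, and the step of a number 32 percentage points higher from compound 1 to compound 3 (beyond the scatter) is large, as is a number 30.2 percentage points higher from compound 2 to compound 3 (beyond the scatter).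

Compound 4, `O=C(CSc1ncccn1)N/N=c1/scc(-c2ccc(Br)cc2)n1-c1ccccc1`, differs from compound 1 by pyrimidin-2-yl in place of 1-phenyl-1H-tetrazol-5-yl on a sulfur. Within the data shown here, none of the measured steps touches this part of the molecule: all three vary the group on the aromatic carbon of the second ring, while the sulfur-bound heterocycle stays the same. Among the measured compounds shown here, no step therefore bears directly on the change, and its direction in this assay cannot be read from the data. The loss of five heavy atoms and two acceptors is a larger alteration than any measured step, so a step beyond the scatter is plausible, with a weaker effect somewhat more likely than a stronger one. Compound 4 is estimated at 35%, within 15% to 65%, a step of a number 14.6 percentage points higher from compound 1 to compound 4 (beyond the scatter) that is expected rather than known.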

Compound 4, a percentage reported as activity, at one concentration (the size of the read-out at that concentration, not a potency): 63.2%
Compound 4: middle estimate off by 28.2 percentage points, on the low side, and the stated range covers the measured number.
By their numbers in this assay, from the lowest: compounds 1 and 2 (each within the scatter of the next); then compound 3; then compound 4.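

The sulfur-linked heterocycle, held fixed across compounds 1 to 3, proves able to shift the read-out in this assay: pyrimidin-2-yl in place of 1-phenyl-1H-tetrazol-5-yl on a sulfur gives a number 42.8 percentage points higher from compound 1 to compound 4 (beyond the scatter), which means a weaker effect at the one concentration tested. The activity of this series therefore depends on this position as well as on the group on the aromatic carbon, where chloro in place of bromo gave a number 32 percentage points higher from compound 1 to compound 3 (beyond the scatter). Nothing measured here accounts for the size or direction of this step.

On these data alone, it remains open whether pyrimidin-2-yl would have a similar effect with chloro or methyl on the aromatic carbon instead of bromo. Also open, as far as these compounds go, is how a 1-methyl-1H-tetrazol-5-yl group or a pyridin-2-yl ring on the sulfur would compare.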